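Methoxy for morpholin-4-yl on the carbonyl carbon

The source may report more compounds than this note shows. Statements on the series, on what has been measured and on what is new or still open speak of the compounds shown alone.

Working notes on a short series around a shared core. Compound 1 `O=C(c1cccc(C#Cc2ccccc2Nc2ncnc3ccc(Cl)nc23)c1)N1CCOCC1` was tested in an assay on isolated protein for inhibition of MAP kinase-interacting serine/threonine-protein kinase 2 (Homo sapiens), read by HTRF, in the presence of a further agent that is not named here (a lower number here means a stronger inhibitor, a higher number a weaker inhibitor), and gave only a limit of the assay, > 10000 nM. This is the limit of > 10000 nM in this assay, at which 1 of the 2 values shown sits, so no number can be set against it. Compound 2 `Cc1c(C(=O)N2CCOCC2)oc2ccc(Nc3ncnc4ccc(Cl)nc34)cc12`, in this assay , gives 1800 nM. Among the measured compounds shown here, that makes compound 2 the only compound here with a measured number; the other value shown is a limit, and nothing more can be said about the pair beyond what the two values show.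

Compound 3 `COC(=O)c1oc2ccc(Nc3ncnc4ccc(Cl)nc34)cc2c1C` is not yet measured in this assay . It differs from compound 2 by methoxy in place of morpholin-4-yl on a carbonyl carbon. For the measured compounds named here, no step between two measured compounds is available as a guide, so the size of the change has to be set from the structural change alone. The step is expected to be small, a 1.4-fold higher number from compound 2 to compound 3 (0.14 log units; within the scatter), within or close to the usual scatter, with no clear direction claimed. For compound 3 the estimate in this assay is 2500 nM, with a range from 800 nM to 8000 nM.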

Compound 3, half-maximal inhibitory concentration: 4800 nM
The estimate for compound 3 lay 1.9-fold (0.28 log units) below the measured number; the range from low to high includes it.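

On the carbonyl carbon, this assay now gives a first readable step, as methoxy in place of morpholin-4-yl produces a 2.7-fold higher number from compound 2 to compound 3 (0.43 log units; beyond the scatter). The position therefore responds to this change, and the morpholin-4-yl group holds the lower number of the pair, although the step is modest and rests on a single pair. Nothing measured here gives a reason for the step.

Among the compounds shown here, compound 1 remains a limit of the assay and differs from the others in more than one place, so no step to it can be read and it adds nothing on this position. The pair leaves open whether the difference follows the ring, the ring oxygen or the change from amide to ester, a question that dimethylamino or piperidin-1-yl on the same carbonyl carbon could separate, while a carboxylic acid or an ethoxy group there could show how far the methoxy result extends.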